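Dichlorophenyl replacing fluoromethylphenyl on the shared core

The source may hold more compounds than are shown below. What is called first, only, known or untested is meant among the compounds shown, and "the series" means these compounds.

Compound 1 `C=CCn1c(=O)/c(=C\c2ccc(Cl)c(Cl)c2)[nH]c(=O)/c1=C\c1ccccc1` is reported in a functional assay on NCI-H1975 cells (Homo sapiens) for cytotoxicity, read by CCK-8 assay, with a stated time of 72 h (on this read-out lower numbers stand for stronger inhibition and higher numbers for weaker inhibition), as "not active" (no number reported). Compound 2 `C=CCn1c(=O)/c(=C\c2cccc(F)c2)[nH]c(=O)/c1=C\c1ccccc1OC` gives 25600 nM in this assay, and compound 3 `C=CCn1c(=O)/c(=C\c2cc(F)ccc2C)[nH]c(=O)/c1=C\c1ccccc1OC` gives 7300 nM; the step of a 3.5-fold lower number from compound 2 to compound 3 (0.54 log units; beyond the scatter) places compound 3 at the lowest of the two numbers, with compound 2 the nearest neighbour. Compound 4 `C=CCn1c(=O)/c(=C\c2cccc(Cl)c2Cl)[nH]c(=O)/c1=C\c1ccccc1OC` carries the change (2,3-dichlorophenyl in place of 5-fluoro-2-methylphenyl on a double-bonded chain carbon bound to an aromatic carbon). Among the compounds with values here, no measured step bears directly on it; the only step at hand is methyl for hydrogen, which is not the change here. Compound 1 with a different dichlorophenyl and a different second ring shows only inactivity, so a higher number than compound 3 is expected, with wide spread: the estimated step is a 2.1-fold higher number from compound 3 to compound 4 (0.31 log units; beyond the scatter), giving compound 4 an expected 15000 nM within 4000 nM to 60000 nM.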

Compound 4, half-maximal inhibitory concentration: 4500 nM
Compound 4: the middle estimate sits 3.3-fold (0.52 log units) above what was measured; the measured number falls inside the stated range.
By their numbers in this assay, from the lowest: compounds 4 and 3 (each within the scatter of the next); then compound 2.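

At the double-bonded chain carbon bound to an aromatic carbon, 2,3-dichlorophenyl and 5-fluoro-2-methylphenyl read alike in this assay, with a 1.6-fold lower number from compound 3 to compound 4 (0.21 log units; within the scatter). Against 3-fluorophenyl, the 2,3-dichlorophenyl group gives a 5.7-fold lower number from compound 2 to compound 4 (0.76 log units; beyond the scatter), so this ring joins 5-fluoro-2-methylphenyl apart from the singly substituted one. Nothing at hand explains these steps. Still open, from the compounds shown here alone, is how a phenyl ring carrying an amine or a carboxylic acid would read at this place, and whether a single chlorine would suffice.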